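The compounds below may be only part of what the source reports. "The series", "measured", "known", "first", "only" and "open" are said of these compounds alone.

Measured so far in a functional assay on COLO 205 cells (Homo sapiens) for inhibition, read by sulforhodamine B assay, with a stated time of 48 h (on this read-out higher numbers stand for weaker inhibition of growth and lower numbers for stronger inhibition of growth), each value a limit of the assay and not a number:

- compound 1 `O=C(Cc1csc2nc(-c3ccc(Br)cc3)cn12)N/N=C/c1ccccc1`: > 100000 nM
- compound 2 `O=C(Cc1csc2nc(-c3ccc(Br)cc3)cn12)N/N=C/c1ccc(O)cc1`: > 100000 nM
- compound 3 `COc1cccc(OC)c1/C=N/NC(=O)Cc1csc2nc(-c3ccc(Br)cc3)cn12`: > 100000 nM

Compound 3 stands at the limit of the series, with no numerical value to start from. The same holds across the set: the limit of > 100000 nM in this assay, at which 3 of the 3 values shown sit.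

Compound 4 `O=C(Cc1csc2nc(-c3ccc(Br)cc3)cn12)N/N=C/c1ccc(Cl)cc1Cl` differs from compound 3 in one place: 2,4-dichlorophenyl in place of 2,6-dimethoxyphenyl on a carbon with a double bond to nitrogen. The 2,4-dichlorophenyl enters where the 2,6-dimethoxyphenyl leaves, on a carbon with a double bond to nitrogen.

For the measured compounds named here, three measured steps bear on this change, since each alters the aromatic group at the same end of the molecule: a step that the two limits leave unreadable from compound 1 to compound 2, a step that the two limits leave unreadable from compound 1 to compound 3 and a step that the two limits leave unreadable from compound 2 to compound 3. None has a readable size, so none gives a size or direction to carry over. Going by the values given here, no measured compound carries a chlorine substituent.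

No readable step is therefore expected in this assay, and a second result at the limit is the likeliest outcome. Any numerical result would be expected on the side of stronger inhibition of growth. The estimated step is a number no higher from compound 3 to compound 4 (the limit leaves the size open). Compound 4 is expected at 100000 nM, within an estimated range of 30000 nM to 100000 nM.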

Compound 4, concentration for total growth inhibition: > 100000 nM
Compound 4: a limit, no number; the forecaster's own chance of this, stated with the estimate: 75%; the middle value sits exactly at the limit.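

In this assay compound 4 gives > 100000 nM, a limit and not a number. No new step can be read between compound 4 and compound 1, compound 2 or compound 3: the limit of > 100000 nM in this assay, at which 4 of the 4 values shown sit.

The compounds shown leave open whether any aromatic group on the carbon with a double bond to nitrogen gives a numerical value in this assay.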